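Swapping the Side-Chain Order: Compound 3 Expected

The compounds below may be only part of what the source reports. "The series", "measured", "known", "first", "only" and "open" are said of these compounds alone.

Compound 1 `COc1cc2nc(N3CCC(OCC(C)(C)OC)CC3)nc(N)c2cc1OC` and compound 2 `CCOCC(OC1CCN(c2nc(N)c3cc(OC)c(OC)cc3n2)CC1)c1ccccc1` share a core and differ only in the group on an oxygen on a saturated carbon; in an assay on brain for displacement of a labelled ligand from Adrenergic receptor alpha-1 (Rattus norvegicus) (a lower number here means a stronger inhibitor, a higher number a weaker inhibitor), compound 1 gives 1.14 nM and compound 2 gives 10 nM, the higher of the two numbers, with an 8.8-fold higher number from compound 1 to compound 2 (0.94 log units; beyond the scatter) between them. Compound 3 `CCOC(COC1CCN(c2nc(N)c3cc(OC)c(OC)cc3n2)CC1)c1ccccc1` carries the same atoms as compound 2, joined differently: 2-ethoxy-2-phenylethyl in place of 2-ethoxy-1-phenylethyl on an oxygen on a saturated carbon. Among the compounds with values here, no measured step concerns such a rearrangement, so no change beyond the scatter is expected, and compound 3 is estimated at 10 nM (range 3 nM to 35 nM), a step of no change at the digits printed from compound 2 to compound 3 (within the scatter).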

Compound 3, inhibition constant: 0.52 nM
Compound 3: the middle estimate sits 19-fold (1.28 log units) above what was measured, outside the stated range (below it).
By their numbers in this assay, from the lowest: compound 3; then compound 1; then compound 2.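

Moving the phenyl ring and the ethoxy group within the side chain, with no atom gained or lost, gives a 19-fold lower number from compound 2 to compound 3 (1.28 log units; beyond the scatter) in this assay, so how these atoms are joined matters at this position, not just which atoms are present. The 2-ethoxy-2-phenylethyl group also compares well with the 2-methoxy-2-methylpropyl group, with a 2.2-fold lower number from compound 1 to compound 3 (0.34 log units; beyond the scatter) in this assay. Nothing available explains the size of these steps. Going by these compounds, whether an amine or a longer chain in place of the ethoxy group would keep the number this low remains open.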